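Swapping a chloro for a nitro on a spiro hydantoin

This account rests on a few compounds, and the source may have more. Where it says the series, first, only, none or still open, it means among the compounds named here.

Measured compounds:
- compound 1, `CN(C)c1ccc(N2C(=O)NC3(CSC4=C3C(=O)c3ncccc3C4=O)C2=O)cc1`: 950 nM
- compound 2, `O=C1NC(=O)C2(CSC3=C2C(=O)c2ncccc2C3=O)N1`: 3100 nM
- compound 3, `O=C1C2=C(C(=O)c3ncccc31)C1(CS2)NC(=O)N(c2ccc(Cl)cc2)C1=O`: 580 nM

Of the compounds shown here, three sharing one core have been tested in a functional assay on SF-268 cells (Homo sapiens) for antiproliferative activity, read by MTT assay, with a stated time of 96 h; on this read-out higher numbers stand for weaker inhibition and lower numbers for stronger inhibition. Compound 1 gives 950 nM, compound 2 gives 3100 nM, and compound 3 gives 580 nM. Compound 3 has the lowest number of the three, though its gap to compound 1 is within the scatter; only its gap to compound 2 is clearly beyond it.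

Compound 4, `O=C1C2=C(C(=O)c3ncccc31)C1(CS2)NC(=O)N(c2ccc([N+](=O)[O-])cc2)C1=O`, is the next step from compound 3. The change is nitro in place of chloro on an aromatic carbon.

Among the measured compounds shown here, no measured pair shows this exact change, so the expectation rests on what surrounds it. Removing the whole aryl group from the ring nitrogen costs activity, as a 3.3-fold higher number from compound 1 to compound 2 (0.51 log units; beyond the scatter) and a 5.3-fold lower number from compound 2 to compound 3 (0.73 log units; beyond the scatter) show. Exchanging the group on that aryl ring mattered little: a 1.6-fold lower number from compound 1 to compound 3 (0.21 log units; within the scatter) stays within the scatter. Since both aryl-bearing compounds sit close together, the nitro analog is expected to stay near them, with no step beyond the scatter, so a 1.0-fold higher number from compound 3 to compound 4 (0.01 log units; within the scatter) is the estimated change.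

Compound 4 is therefore expected to give about 600 nM in this assay, within a range from 250 nM to 1500 nM.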

Compound 4, half-maximal inhibitory concentration: 1520 nM
For compound 4 the middle estimate is 2.5-fold (0.40 log units) below the measured one, and the stated range ends below it.
By their numbers in this assay, from the lowest: compounds 3, 1 and 4 (each within the scatter of the next, the first and the last beyond it); then compound 2.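

In this assay, the group on the aryl ring now proves able to shift the result at this position: swapping chloro for nitro gives a step beyond the scatter (a 2.6-fold higher number from compound 3 to compound 4 (0.42 log units; beyond the scatter)), whereas the earlier exchange of dimethylamino for chloro stayed within it. The 4-nitrophenyl group still improves on the hydrogen on the ring nitrogen (a 2.0-fold lower number from compound 2 to compound 4 (0.31 log units; beyond the scatter)), though by a smaller step than the 4-chlorophenyl group does (a 5.3-fold lower number from compound 2 to compound 3 (0.73 log units; beyond the scatter)), and the nitro and dimethylamino compounds cannot be told apart (a 1.6-fold higher number from compound 1 to compound 4 (0.20 log units; within the scatter)). Nothing available here accounts for the difference between the chloro and nitro compounds.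

Going by these compounds, with only chloro, nitro and dimethylamino on this aryl ring, it remains open whether a fluoro, a methoxy or a carboxylic acid in the same place would track with compound 3 or with compound 4. Also open, on these data alone, is whether a simple alkyl chain or a benzyl group on the ring nitrogen could replace the aryl ring and still improve on compound 2.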